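The compounds below may be only part of what the source reports. "The series", "measured", "known", "first", "only" and "open" are said of these compounds alone.

Measured so far in an ADME assay on HCT-116 cells (Homo sapiens) for cytotoxicity, read by CellTiter-Glo, with a stated time of 72 h; on this read-out lower numbers stand for stronger inhibition and higher numbers for weaker inhibition:
- compound 1 `COc1ccccc1-c1cccc(S(=O)(=O)N2CCC(N3CCC(C)CC3)CC2)c1`: a limit only, > 5000 nM
- compound 2 `CCc1ccc(S(=O)(=O)N2CCC(N3CCC(C)CC3)CC2)cc1`: a limit only, > 5000 nM
- compound 3 `CC1CCN(C2CCN(S(=O)(=O)c3cccc4cnccc34)CC2)CC1`: a limit only, > 10000 nM

Compound 1 therefore stands at the limit of this assay, and the two other values shown are limits too; no number has been reached for any of the three. Compound 1 sits at the limit of > 5000 nM in this assay, at which 2 of the 3 values shown sit. Compound 3 sits at the limit of > 10000 nM in this assay, at which 1 of the 3 values shown sits. Compound 4 `COc1ccc(-c2cccc(S(=O)(=O)N3CCC(N4CCC(C)CC4)CC3)c2)cc1` differs from compound 1 by 4-methoxyphenyl in place of 2-methoxyphenyl on an aromatic carbon. Among the measured compounds shown here, no step between measured compounds is available, and the three values shown give no ranking. In this assay the step from compound 1 to compound 4 is expected to be none beyond the scatter, with compound 4 expected to stay at the limit as well. The expected step is a step that the limit leaves unreadable from compound 1 to compound 4. Compound 4 is estimated at 8000 nM, within 3000 nM to 25000 nM.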

Compound 4, half-maximal inhibitory concentration: > 5000 nM
Compound 4 was reported as a limit; the forecaster's own chance of this, stated with the estimate: 85%; the middle value is on the limit's open side.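

Compound 1 and compound 4 both stand at a limit in this assay, so no step can be read between them. The compounds shown leave open whether 2-methoxyphenyl and 4-methoxyphenyl differ at all in this read-out.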